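The source may hold more compounds than are shown below. What is called first, only, known or untested is meant among the compounds shown, and "the series" means these compounds.

Compound 3 `C=C1CC[C@@H]2[C@](C)(CO)[C@H](O)CC[C@@]2(C)[C@@H]1CCC1=CCOC1=O` gives 25500 nM in a functional assay on HL-60 cells (Homo sapiens) for antiproliferative activity, read by trypan blue exclusion; a higher number here means a weaker inhibitor of growth, a lower number a stronger inhibitor of growth. Compound 1 `C=C1[C@H](O)C[C@@H]2[C@](C)(CO)[C@H](O)CC[C@@]2(C)[C@@H]1CCC1=CCOC1=O` gives 22500 nM and compound 2 `C=C1CC[C@@H]2[C@](C)(CO)CCC[C@@]2(C)[C@@H]1CCC1=CCOC1=O` gives 20000 nM, so the three numbers sit close together, with a 1.1-fold higher number from compound 1 to compound 3 (0.05 log units; within the scatter) and a 1.3-fold higher number from compound 2 to compound 3 (0.11 log units; within the scatter), both within the scatter. Compound 4 `C=C1CC[C@@H]2[C@](C)(CO)[C@H](O)CC[C@@]2(C)[C@@H]1CC/C(=C/CO)C(=O)O` differs from compound 3 by a group of 7 heavy atoms (4 carbon, 3 oxygen; no ring) in place of a group of 6 heavy atoms (4 carbon, 2 oxygen; one five-membered non-aromatic ring with 1 hetero atom), on a saturated chain carbon, two bonds along the chain from a saturated ring carbon. Going by the values given here, the two measured steps concern a hydroxy on a saturated ring carbon and do not touch this place; no step in the set bears on opening the five-membered ring. Among the compounds with values here, the outcome in this assay therefore rests on no prior step, and a modest drift toward a higher number is expected, as a 1.3-fold higher number from compound 3 to compound 4 (0.10 log units; within the scatter). Compound 4 is accordingly expected to give 32000 nM, within 10000 nM to 100000 nM.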

Compound 4, concentration for 50% growth inhibition: 22400 nM
Compound 4: middle estimate off by 1.4-fold (0.15 log units), on the high side, and the stated range covers the measured number.
By their numbers in this assay, from the lowest: compounds 2, 4, 1 and 3 (each within the scatter of the next).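

In this assay, the open group with no ring in place of the five-membered ring group gives a 1.1-fold lower number from compound 3 to compound 4 (0.06 log units; within the scatter), so this saturated chain carbon tolerates that exchange with the number staying within the scatter. The earlier steps shown here concerned only a hydroxy on a saturated ring carbon, and this step shows that, at this level of growth inhibition, the five-membered ring is not required. No measurement shown gives an explanation for this result. The compounds shown leave open how an amine, an amide or a longer chain at this place would read. They also leave open whether any group here moves the number beyond the scatter.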